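The source may report more compounds than this note shows. Statements on the series, on what has been measured and on what is new or still open speak of the compounds shown alone.

In a functional assay on MCF7 cells (Homo sapiens) for inhibition, read by CCK-8 assay, with a stated time of 48 h (on this read-out higher numbers stand for weaker inhibition and lower numbers for stronger inhibition), compound 1 (`COc1ccc(-c2cc3nccc(-c4cc(OC)c(OC)c(OC)c4)n3n2)cc1`) gives 125 nM and compound 2 (`COc1ccc(-c2cc3nccc(-c4cc(OC)c(OC)c(OC)c4)n3n2)cc1F`) gives 183 nM. These two numbers lie within the scatter of each other, so compound 2 stands level with compound 1 on the evidence so far.

Compound 3 (`COc1cc(-c2ccnc3cc(-c4ccc(C(C)(C)C)cc4)nn23)cc(OC)c1OC`) keeps the shared core and carries 4-(tert-butyl)phenyl in place of 3-fluoro-4-methoxyphenyl on an aromatic carbon. For the measured compounds named here, only one measured step bears on this change: a 1.5-fold higher number from compound 1 to compound 2 (0.17 log units; within the scatter), for fluoro in place of hydrogen on an aromatic carbon. That step lies within the scatter and suggests that the fluoro leaving matters little. Going by the values given here, it says nothing about losing the methoxy or gaining the tert-butyl, since no measured compound lacks the methoxy or carries the tert-butyl. The size of the step therefore remains poorly defined, and a modest move toward weaker inhibition in this assay is only a cautious expectation. The expected change is a 2.2-fold higher number from compound 2 to compound 3 (0.34 log units; beyond the scatter). For compound 3 the estimated value is 400 nM, with an expected range from 100 nM to 1800 nM.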

Compound 3, half-maximal inhibitory concentration: > 10000 nM
Compound 3 gave a limit, no number (the forecaster's own chance of this, stated with the estimate: 3%); middle value at least 25-fold (1.39 log units) from the limit.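

Compound 3 gave a limit rather than a number: the limit of > 10000 nM in this assay, at which 1 of the 3 values shown sits. This aryl group on an aromatic carbon of the five-membered ring is therefore far from indifferent to change: 4-(tert-butyl)phenyl in place of 3-fluoro-4-methoxyphenyl gives an at least 54-fold higher number from compound 2 to compound 3 (1.73 log units; beyond the scatter), and tert-butyl in place of methoxy gives an at least 80-fold higher number from compound 1 to compound 3 (1.90 log units; beyond the scatter), both large moves toward weaker inhibition in this assay. For the compounds shown here, the fluoro change alone had stayed within the scatter, at a 1.5-fold higher number from compound 1 to compound 2 (0.17 log units; within the scatter), so the earlier compounds showed one change on this aryl group that left the read-out unmoved, whereas compound 3 shows that this aryl group can also carry a change that costs most of the inhibition.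

The compounds shown do not separate losing the methoxy from gaining the tert-butyl, and a plain phenyl or a 4-methylphenyl group in the same place would be needed to tell those two apart. They also leave open how a hydroxy group, an amine or a carboxylic acid on this aryl group would read in this assay.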